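Shortening the chain on the piperazine side of compound 3

The source may hold more compounds than are shown below. What is called first, only, known or untested is meant among the compounds shown, and "the series" means these compounds.

The series shares one core. Compound 1 `Cc1ccc2oc(-c3ccc(NC(=O)CN4CCN(CCCN(C)C)CC4)cc3)nc2c1` gives 3160 nM in a functional assay on HepG2 cells (Homo sapiens) for cytotoxicity, read by MTT assay, with a stated time of 24 h; a lower number here means a stronger inhibitor, a higher number a weaker inhibitor. Compound 2 `Cc1ccc2oc(-c3ccc(NC(=O)CN4CCN(CCCN(C)C)CC4)c(C)c3)nc2c1` gives 5650 nM, and compound 3 `CN(C)CCCN1CCN(CC(=O)Nc2ccc(-c3nc4ccccc4o3)cc2)CC1` gives 9500 nM. Of the two steps recorded, one is a 1.8-fold higher number from compound 1 to compound 2 (0.25 log units; within the scatter) and the other is a 3.0-fold higher number from compound 1 to compound 3 (0.48 log units; beyond the scatter). Compound 3 therefore sits beyond the scatter above compound 1, while its number and that of compound 2 lie within the scatter of each other.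

Compound 4 `CN(C)CCN1CCN(CC(=O)Nc2ccc(-c3nc4ccccc4o3)cc2)CC1` differs from compound 3 by dimethylamino in place of (dimethylamino)methyl on a saturated chain carbon, two bonds along the chain from an amine nitrogen in a ring. Within the data shown here, both recorded steps concern a methyl on an aromatic carbon of the core; neither touches the saturated chain on the amine nitrogen in a ring, so no measured step bears on this change. With nothing in the data to point in either direction, no movement beyond the scatter is expected, and compound 4 is estimated to stay near compound 3.

The expected step is no change at the digits printed from compound 3 to compound 4 (within the scatter). For compound 4 the estimate in this assay is 9500 nM, with a range from 4000 nM to 22000 nM.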

Compound 4, half-maximal inhibitory concentration: 16300 nM
Compound 4: middle estimate off by 1.7-fold (0.23 log units), on the low side; low and high end bracket the measured number.
By their numbers in this assay, from the lowest: compounds 1, 2, 3 and 4 (each within the scatter of the next, the first and the last beyond it).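

In this assay, among these compounds, the step from 3-(dimethylamino)propyl to 2-(dimethylamino)ethyl on the amine nitrogen in a ring gives a 1.7-fold higher number from compound 3 to compound 4 (0.23 log units; within the scatter) and is the first measured change to the saturated chain, since the earlier steps concerned only a methyl on an aromatic carbon of the core. Within this single pair, removing one chain carbon therefore moves the number by no more than the usual scatter, so the shorter chain cannot be separated from the longer one in this assay. Nothing available here explains the size or direction of this step.

One pair cannot show whether the same shortening would behave alike on the methyl-bearing cores of compound 1 and compound 2, where the starting numbers differ. It also leaves open how this position would respond to a longer chain such as 4-(dimethylamino)butyl, to a terminal diethylamino or morpholine group in place of dimethylamino, or to a terminal hydroxyl with no amine at the chain end.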